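This account rests on a few compounds, and the source may have more. Where it says the series, first, only, none or still open, it means among the compounds named here.

Series notes. Compound 1 `CCOc1ccc2oc(/C=C/[S+](C)[O-])cc(=O)c2c1`, compound 2 `CCCCOc1ccc2oc(/C=C/[S+](C)[O-])cc(=O)c2c1` and compound 3 `CCCOc1ccc2oc(/C=C/[S+](C)[O-])cc(=O)c2c1` share one core and differ only in the chain on the oxygen on the aromatic ring. In a functional assay on DLD-1 cells (Homo sapiens) for cytotoxicity, with a stated time of 48 h (a higher number here means a weaker inhibitor, a lower number a stronger inhibitor), compound 1 gives 4900 nM, compound 2 gives 4800 nM and compound 3 gives 6200 nM; every step among these three is within the scatter. The change hydrogen in place of ethyl on a saturated chain carbon, two bonds along the chain from an oxygen on an aromatic ring gave a 1.0-fold higher number from compound 2 to compound 1 (0.01 log units; within the scatter). Compound 4 `COc1ccc2oc(/C=C/[S+](C)[O-])cc(=O)c2c1` is not yet measured and arises from compound 3 by hydrogen in place of ethyl on a saturated chain carbon bound to an oxygen on an aromatic ring. The cores of compound 2 and compound 3 differ by hydrogen in place of methyl on a saturated chain carbon, three bonds along the chain from an oxygen on an aromatic ring. The place also differs: in the measured pair the carbon is two bonds along the chain from the oxygen on the aromatic ring, here it is bound to that oxygen, so this is the same kind of change, not the same one. Because a 1.0-fold higher number from compound 2 to compound 1 (0.01 log units; within the scatter) lies within the scatter, the step of a 1.0-fold higher number from compound 3 to compound 4 (0.02 log units; within the scatter) is expected to be small too. Compound 4 is estimated at 6500 nM, between 3000 nM and 14000 nM.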

Compound 4, half-maximal inhibitory concentration: 5700 nM
The estimate for compound 4 lay 1.1-fold (0.06 log units) above the measured number; measured number inside the range.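

In this assay, going by these compounds alone, the new steps are a 1.1-fold lower number from compound 3 to compound 4 (0.04 log units; within the scatter), a 1.2-fold higher number from compound 2 to compound 4 (0.07 log units; within the scatter) and a 1.2-fold higher number from compound 1 to compound 4 (0.07 log units; within the scatter), so the agreement between cores shows only that these chain changes leave the number within the scatter on each core, not that a change with a larger step would carry over in the same way. Hydrogen in place of ethyl reads alike on both cores: the same change on two cores in this assay, a 1.0-fold higher number (0.01 log units; within the scatter) from compound 2 to compound 1 and a 1.1-fold lower number (0.04 log units; within the scatter) from compound 3 to compound 4, 1.1-fold (0.05 log units) apart, within the scatter of two such steps The removal of the chain end reads alike as well: the same change on two cores in this assay, a 1.3-fold higher number (0.11 log units; within the scatter) from compound 2 to compound 3 and a 1.2-fold higher number (0.07 log units; within the scatter) from compound 1 to compound 4, 1.1-fold (0.05 log units) apart, within the scatter of two such steps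

The compounds shown leave open whether a much longer chain, or an amine or a carboxylic acid at the end of the chain on the oxygen, would move the number beyond the scatter. Changes elsewhere on the shared core also remain open.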